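From acetyl to trifluoromethyl: what compound 4 may give

The compounds below may be only part of what the source reports. "The series", "measured", "known", "first", "only" and "open" are said of these compounds alone.

Compound 1 `Nc1sc(-c2ccccc2)c(-c2cccc(C(F)(F)F)c2)c1C(=O)c1ccccc1`: in an assay on CHO-K1 cells for displacement of a labelled ligand from adenosine receptor A1 (Homo sapiens), tested at 10 uM (a higher number here means more inhibition at the concentration tested (going by the name of the read-out), a lower number less inhibition), compound 1 gives 82.4%
Compound 2 `CC(=O)c1ccc(-c2sc(N)c(C(=O)c3ccccc3)c2-c2cccc(C(F)(F)F)c2)cc1`: compound 2 gives 25.6%
Compound 3 `CCOC(=O)c1c(N)sc(-c2ccc(C(C)=O)cc2)c1-c1cccc(C(F)(F)F)c1`: compound 3 gives 64.6%

Among these three numbers compound 3 stands second highest: compound 1 lies above it, and compound 2 lies well below it, the latter gap being the measured step of a number 39 percentage points higher from compound 2 to compound 3 (beyond the scatter), which traded the phenyl on the carbonyl carbon for ethoxy.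

The next compound, compound 4 `CCOC(=O)c1c(N)sc(-c2ccc(C(F)(F)F)cc2)c1-c1cccc(C(F)(F)F)c1`, keeps the ester of compound 3 and changes only the substituent on the pendant phenyl: trifluoromethyl in place of acetyl on an aromatic carbon.

The step that bears most directly on this change is a number 56.8 percentage points lower from compound 1 to compound 2 (beyond the scatter), where acetyl entered on the same aromatic carbon and inhibition fell sharply, though in the phenyl-ketone rather than the ester series. Among the compounds with values here, removing that acetyl would therefore be expected to recover some inhibition; that trifluoromethyl rather than hydrogen takes its place has no measured counterpart here, so the size is uncertain. A moderate rise is expected, a number 13.4 percentage points higher from compound 3 to compound 4 (beyond the scatter), beyond the scatter but not necessarily back to the level of compound 1.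

Compound 4 is estimated to give 78% in this assay, within a range from 55% to 95%.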

Compound 4, a percentage reported as inhibition, at one concentration (the size of the read-out at that concentration, not a potency): 48.5%
Compound 4: the middle estimate sits 29.5 percentage points above what was measured; measured number outside the range, below it.
By their numbers in this assay, from the lowest: compound 2; then compound 4; then compound 3; then compound 1.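

With the ester held fixed, going from 4-acetylphenyl to 4-(trifluoromethyl)phenyl lowers the read-out in this assay, with a number 16.1 percentage points lower from compound 3 to compound 4 (beyond the scatter). Up to this point, the only measured change at this aromatic carbon was the entry of acetyl in place of hydrogen in the phenyl-ketone series, a number 56.8 percentage points lower from compound 1 to compound 2 (beyond the scatter), which cast acetyl as a group that costs inhibition. The new step shows that in the ester series acetyl gives more inhibition than trifluoromethyl at the same place, so the loss seen on adding acetyl does not carry over as a rule that replacing acetyl restores inhibition.

Nothing available explains why trifluoromethyl gives less inhibition than acetyl here. Going by these compounds, it remains open how the ester with plain hydrogen on this aromatic carbon would compare with these two, and whether a methoxy group, a nitrile, an amine or a carboxylic acid at the same place would stand nearer compound 3 or compound 4, or outside the span of both.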